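This account rests on a few compounds, and the source may have more. Where it says the series, first, only, none or still open, it means among the compounds named here.

Compound 3 `CCCSc1nc(N/N=C/c2cccc(Cl)c2)c2nnn(Cc3ccccc3)c2n1` sits at a limit in a functional assay on MCF7 cells (Homo sapiens) for antiproliferative activity, read by MTT assay, with a stated time of 72 h (a lower number here means a stronger inhibitor, a higher number a weaker inhibitor), where compound 3 gives > 64000 nM. Compound 1 `CCCSc1nc(N/N=C/c2ccc(Cl)cc2)c2nnn(Cc3ccccc3)c2n1` also sits at a limit, giving > 64000 nM in this assay, so the step that the two limits leave unreadable from compound 1 to compound 3 is not readable; this is what the limit of > 64000 nM in this assay, at which 2 of the 3 values shown sit, expresses. Among the measured compounds shown here, compound 2 `C/C(=N\Nc1nc(SCc2ccccc2)nc2c1nnn2Cc1ccccc1)c1ccccc1O` is the one measured number, giving 950 nM in this assay. Compound 4 `CCCSc1nc(N/N=C(\C)c2ccccc2O)c2nnn(Cc3ccccc3)c2n1` differs from compound 3 by a group of 10 heavy atoms (8 carbon, 1 nitrogen, 1 oxygen; one six-membered aromatic ring of carbon only) in place of a group of 9 heavy atoms (7 carbon, 1 nitrogen, 1 chlorine; one six-membered aromatic ring of carbon only), on a nitrogen on an aromatic ring. For the measured compounds named here, no measured step follows this exact change, so the size can only be guessed. Because compound 2 carries the same entering group and gives 950 nM, compound 4 is expected to move into the measurable range, a step of an at least 12-fold lower number from compound 3 to compound 4 (1.10 log units; beyond the scatter) in this assay, with an estimated value of 5000 nM spanning 800 nM to 40000 nM.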

Compound 4, half-maximal inhibitory concentration: 11000 nM
Compound 4: the middle estimate sits 2.2-fold (0.34 log units) below what was measured; the measured number falls inside the stated range.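

The change on a nitrogen on an aromatic ring gives compound 4 a readable value, whereas neither chlorophenyl compound had one: in this assay the steps are an at least 5.8-fold lower number from compound 3 to compound 4 (0.76 log units; beyond the scatter) and an at least 5.8-fold lower number from compound 1 to compound 4 (0.76 log units; beyond the scatter). Both steps start from a limit and not from a number: the limit of > 64000 nM in this assay, at which 2 of the 4 values shown sit. With the entering group held constant, ethyl in place of phenyl on a saturated chain carbon bound to a sulfur gives a 12-fold higher number from compound 2 to compound 4 (1.06 log units; beyond the scatter), so this second place also matters.

As far as these compounds go, it remains open which part of the entering group, its methyl or its hydroxyl, carries the first change. From the compounds shown here alone, how an amine or a longer chain in place of that ethyl would read also remains open.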